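A few compounds are considered here, and "the series" means these few. Any claim that something is new, unique, unknown or untested is made for them only; others in the source may bear on it.

Measured so far:
- Compound 1 `O=C(Nc1ccc(Cl)cc1)c1cc([N+](=O)[O-])ccc1Cl`; in an ADME assay on BJ cells (Homo sapiens) for inhibition, with a stated time of 72 h (on this read-out higher numbers stand for an effect only at larger amounts of compound and lower numbers for an effect already at smaller amounts), compound 1 gives > 25000 nM, which is a limit of the assay rather than a number.
- Compound 2 `C=CC(=O)Nc1cccc(-c2nc3ccccc3s2)c1`; in this assay compound 2 gives > 25000 nM, again a limit and not a number.

Compound 2 therefore stands at the edge of what this assay can report, and it does not stand alone there: the limit of > 25000 nM in this assay, at which 2 of the 2 values shown sit. Nothing in the numbers shown separates compound 2 from compound 1, and no step between two measured compounds is given at all, so there is no measured change to learn from.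

Compound 3 `C/C=C/C(=O)Nc1cccc(-c2nc3ccccc3s2)c1` is the next compound to be measured. It differs from compound 2 in one place: prop-1-en-1-yl in place of vinyl on a carbonyl carbon, that is, a prop-1-en-1-yl in place of vinyl on a carbonyl carbon whose other neighbour is an amide-type nitrogen. Among the compounds with values here, with no measured step to lean on, the expectation for this assay is no change beyond the scatter, and the most probable outcome is that compound 3 also returns only a limit. The expected step from compound 2 to compound 3 is a step that the limit leaves unreadable from compound 2 to compound 3. For compound 3 the estimated value is 30000 nM, within a range from 8000 nM to 120000 nM.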

Compound 3, half-maximal effective concentration: > 25000 nM
Compound 3 was reported as a limit; the forecaster's own chance of this, stated with the estimate: 80%; the middle value is on the limit's open side.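

Compound 2 and compound 3 are both reported only as limits, so no step from vinyl to prop-1-en-1-yl can be read between them: the limit of > 25000 nM in this assay, at which 3 of the 3 values shown sit.

The compounds shown leave open how vinyl and prop-1-en-1-yl on this carbonyl carbon compare, and whether any of these compounds would give an actual number in this assay.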